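The source may report more compounds than this note shows. Statements on the series, on what has been measured and on what is new or still open speak of the compounds shown alone.

In an ADME assay for permeability (a higher number here means that the compound crosses the layer faster, a lower number that the compound crosses the layer more slowly), compound 1 `CC[C@@H](c1ccccc1)n1nc(C(=O)NC)cc1C(=O)N[C@H]1[C@@H]2C[C@@H](O)C[C@@H]21` gives 120 nm/s. Compound 2 `CC[C@@H](c1ccccc1)n1nc(C(=O)NC)cc1C(=O)N[C@H]1[C@@H]2C[C@H](O)C[C@@H]21`, which differs from it only in configuration as drawn, gives 230 nm/s. Compound 3 `CC[C@@H](c1ccccc1)n1nc(C(=O)NC)cc1C(=O)N[C@H]1CC[C@H](O)CC1`, with a six-membered carbon ring on the amide-type nitrogen, gives 70 nm/s. Compound 1 is the middle one of these three numbers, but it lies within the scatter of both others: the steps are a 1.9-fold higher number from compound 1 to compound 2 (0.28 log units; within the scatter) and a 1.7-fold lower number from compound 1 to compound 3 (0.23 log units; within the scatter). Only a 3.3-fold lower number from compound 2 to compound 3 (0.52 log units; beyond the scatter) passes beyond the scatter.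

Compound 4 `CNC(=O)c1cc(C(=O)N[C@H]2[C@@H]3C[C@@H](O)C[C@@H]32)n([C@@H](C)c2ccccc2)n1` keeps the group on the amide-type nitrogen of compound 1 and changes the other side: hydrogen in place of methyl on a saturated chain carbon, two bonds along the chain from an aromatic carbon and an aromatic nitrogen. In this way 1-phenylpropyl becomes 1-phenylethyl. All three measured steps alter the group on the amide-type nitrogen, and none touches the 1-phenylpropyl group, so they bear on this change only indirectly, as a guide to how far the numbers spread. The expected step is a 1.1-fold lower number from compound 1 to compound 4 (0.06 log units; within the scatter), which means no firm direction and nothing beyond the scatter. For compound 4 the estimated value in this assay is 105 nm/s, with an expected range from 50 nm/s to 220 nm/s.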

Compound 4, apparent permeability: 61 nm/s
For compound 4 the middle estimate is 1.7-fold (0.24 log units) above the measured one; measured number inside the range.
By their numbers in this assay, from the lowest: compounds 4, 3, 1 and 2 (each within the scatter of the next, the first and the last beyond it).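

For the compounds shown here, on the side of the core that the earlier steps left untouched, cutting ethyl to methyl, so that 1-phenylpropyl becomes 1-phenylethyl, gives a 2.0-fold lower number from compound 1 to compound 4 (0.29 log units; within the scatter) in this assay. Going by these compounds alone, this is the first direct reading of a change on this saturated chain carbon, and with the group on the amide-type nitrogen held as in compound 1, it sets no firm direction for the change. What is known about compounds 1 and 2 concerns the other side of the core and offers no explanation for this step.

Going by these compounds, whether a longer chain such as propyl, or a hydroxyl group, at this place would move the number beyond the scatter remains open. On these data alone, it is also open whether the same cut from ethyl to methyl would read alike with the group on the amide-type nitrogen of compound 2 or compound 3.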